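The source may hold more compounds than are shown below. What is called first, only, known or untested is meant among the compounds shown, and "the series" means these compounds.

Working notes on the series. Compound 3 `CSc1ccc(/C(=N\OCCCCN2CCCC2)c2cccc3ccccc23)cc1` carries the shared core with a pyrrolidin-1-yl group on the chain. In a functional assay on Ishikawa cells (Homo sapiens) for antiproliferative activity, read by MTT assay, with a stated time of 24 h (a lower number here means that less compound is needed, a higher number that more compound is needed for the effect), compound 3 gives only the limit > 50000 nM. Compound 2 `CSc1ccc(/C(=N\OCCCCN2CCCCC2)c2cccc3ccccc23)cc1` gives 18000 nM in this assay. Compound 1 `CCCCN(C)CCCO/N=C(\c1ccc(SC)cc1)c1cccc2ccccc12` gives the limit > 50000 nM in this assay. The readable steps are an at least 2.7-fold higher number from compound 2 to compound 3 (0.44 log units; beyond the scatter) and an at least 2.7-fold lower number from compound 1 to compound 2 (0.44 log units; beyond the scatter), while a step that the two limits leave unreadable from compound 1 to compound 3. Going by the values given here, two of the three values are thus limits, not numbers, and compound 2 is the only one giving a number.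

Compound 4 `CCN(CCCCO/N=C(\c1ccc(SC)cc1)c1cccc2ccccc12)Cc1ccccc1` differs from compound 3 by benzyl(ethyl)amino in place of pyrrolidin-1-yl on a saturated chain carbon, four bonds along the chain from an oxygen. Among the compounds with values here, compound 4 therefore carries an acyclic tertiary amine, as does compound 1, whose value is a limit; the only step with a readable direction, from compound 2 to compound 3, runs between two ring amines and bears on compound 4 only indirectly. Since the limit of > 50000 nM in this assay, at which 2 of the 3 values shown sit, holds for two of three compounds, another limit for compound 4 is plausible. Compound 4 is expected to give 40000 nM, within 12000 nM to 120000 nM. The expected step is an at least 1.2-fold lower number from compound 3 to compound 4 (0.09 log units; that floor lies within the scatter).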

Compound 4, half-maximal effective concentration: > 50000 nM
Compound 4: only a limit was reported; the forecaster's own chance of this, stated with the estimate: 45%; middle value at least 1.2-fold (0.09 log units) away from the limit.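

In this assay compound 4 gives > 50000 nM, which is a limit and not a number. Benzyl(ethyl)amino in place of piperidin-1-yl on a saturated chain carbon, four bonds along the chain from an oxygen, gives an at least 2.7-fold higher number from compound 2 to compound 4 (0.44 log units; beyond the scatter), so a second group at this place, after pyrrolidin-1-yl, loses the readable value of compound 2. The steps to compound 4 from compound 1 and compound 3 cannot be read, and compound 2 stays the only one of the four with a number, the others sitting at one limit: the limit of > 50000 nM in this assay, at which 3 of the 4 values shown sit.

On these data alone, how the compounds at the limit rank among themselves stays open. A morpholin-4-yl or azepan-1-yl group on the same chain would show whether a readable value is tied to piperidin-1-yl alone.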